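Adding chloro to compound 3

The compounds below may be only part of what the source reports. "The series", "measured", "known", "first", "only" and "open" are said of these compounds alone.

In a functional assay on PC-3 cells (Homo sapiens) for antiproliferative activity, read by MTT assay, with a stated time of 96 h (on this read-out lower numbers stand for stronger inhibition of growth and higher numbers for weaker inhibition of growth), compound 3 `Oc1cccc2ccc(Sc3ccccn3)nc12` gives 20900 nM while compound 1 `Cc1ccnc(Nc2ccc3ccccc3n2)c1` gives 26700 nM and the two lie within the scatter of each other. For compound 2 `Clc1ccnc(Nc2ccc3ccccc3n2)c1` the value > 30000 nM is a limit. The change to compound 4 `Oc1ccc(Cl)c2ccc(Sc3ccccn3)nc12` is chloro in place of hydrogen on an aromatic carbon and it sits para to a hydroxy group. Going by the values given here, the one measured step that brings in chloro starts from methyl, not hydrogen, and an at least 1.1-fold higher number from compound 1 to compound 2 (0.05 log units; that floor lies within the scatter) offers only weak guidance here. No step beyond the scatter is therefore expected in this assay for this change. The estimated step is a 1.4-fold lower number from compound 3 to compound 4 (0.14 log units; within the scatter) and it remains an expectation. For compound 4 the expected value is 15000 nM with an estimated range from 4000 nM to 30000 nM until it is measured.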

Compound 4, concentration for 50% growth inhibition: 10200 nM
The estimate for compound 4 lay 1.5-fold (0.17 log units) above the measured number, and the stated range covers the measured number.
By their numbers in this assay, from the lowest: compound 4; then compounds 3 and 1 (each within the scatter of the next). At a limit, above all of these: compound 2.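

In this assay, going by these compounds alone, chloro in place of hydrogen on an aromatic carbon, para to a hydroxy group, gives a 2.0-fold lower number from compound 3 to compound 4 (0.31 log units; beyond the scatter) and this is the first step here beyond the scatter, though a modest one. The earlier chloro step started from methyl on another core and its floor stayed within the scatter, so only now does chloro show stronger inhibition of growth. As far as these compounds go, whether an amine, a methoxy group or bromo at this same place would give a step of similar size stays open. Nothing shown here bears on why the step arises.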